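Working notes: from compound 2 to compound 3

This account rests on a few compounds, and the source may have more. Where it says the series, first, only, none or still open, it means among the compounds named here.

Measured in a functional assay on MDA-MB-231 cells (Homo sapiens) for inhibition, read by MTT assay, with a stated time of 72 h; on this read-out higher numbers stand for weaker inhibition and lower numbers for stronger inhibition
Compound 1 `COc1ccc(-c2cc(C(=O)N3CCC4(CC3)CC(=O)c3nn(C(C)(C)C)cc3O4)c3ccccc3n2)cc1`: > 10000 nM
Compound 2 `COc1ccc(-c2cc(C(=O)N3CCC4(CC3)CC(=O)c3nn(C(C)(C)C)cc3O4)c3ccccc3n2)cc1OC`: 7130 nM

Compound 1 gives > 10000 nM as a limit of the assay and not as a number. Among the compounds with values here, compound 2 gives 7130 nM as the only number so far. Compound 3 `CC(C)(C)n1cc2c(n1)C(=O)CC1(CCN(C(=O)c3cc(-c4ccccn4)nc4ccccc34)CC1)O2` carries the change pyridin-2-yl in place of 3,4-dimethoxyphenyl on an aromatic carbon next to the ring nitrogen. Within the data shown here, the one measured step of an at least 1.4-fold lower number from compound 1 to compound 2 (0.14 log units; that floor lies within the scatter) is methoxy in place of hydrogen on an aromatic carbon and is the only guide, so no step beyond the scatter is expected in this assay for this change. The estimated step is a 1.1-fold higher number from compound 2 to compound 3 (0.05 log units; within the scatter) and stays within the scatter. For compound 3 the estimate is 8000 nM with an expected range from 3000 nM to 20000 nM and a real chance of a limit instead of a number.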

Compound 3, half-maximal inhibitory concentration: 8100 nM
Compound 3: middle estimate off by 1.0-fold (0.01 log units), on the low side; low and high end bracket the measured number.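

In this assay, pyridin-2-yl in place of 3,4-dimethoxyphenyl on the aromatic carbon next to the ring nitrogen gives a 1.1-fold higher number from compound 2 to compound 3 (0.06 log units; within the scatter), so neither methoxy group nor an all-carbon ring is required for a value in this range. Pyridin-2-yl in place of 4-methoxyphenyl gives an at least 1.2-fold lower number from compound 1 to compound 3 (0.09 log units; that floor lies within the scatter). Compound 1 stands at a limit of the assay and not at a number, so this comparison yields only a floor: the limit of > 10000 nM in this assay, at which 1 of the 3 values shown sits.

No group shown at this position gives a step beyond the scatter. Open, on these data alone, is whether an amine, a carboxylic acid or a longer chain on this carbon would do so.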